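A few compounds are considered here, and "the series" means these few. Any claim that something is new, unique, unknown or untested is made for them only; others in the source may bear on it.

Series notes. Compound 1 `O=c1[nH]c(=O)n([C@H]2C[C@H](O)[C@@H](CO)O2)cc1[N+](=O)[O-]` is the reference point: in an ADME assay on L1210/0 cells (Mus musculus) for cytotoxicity, with a stated time of 48 h (on this read-out higher numbers stand for weaker inhibition and lower numbers for stronger inhibition), compound 1 gives 130 nM. Compound 2 `CS(=O)(=O)Cc1cn([C@H]2C[C@H](O)[C@@H](CO)O2)c(=O)[nH]c1=O` carries (methylsulfonyl)methyl in place of nitro on an aromatic carbon. For compound 2 in this assay only a limit is recorded, > 200000 nM. Within the data shown here, the single measured step, an at least 1500-fold higher number from compound 1 to compound 2 (3.18 log units; beyond the scatter), is the only one that touches compound 2, and its size rests on the limit of > 200000 nM in this assay, at which 1 of the 2 values shown sits, rather than on a measured number. On the numbers shown, compound 2 therefore stands at the weak end of the pair, without a value of its own.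

Compound 3 `C#COc1cn([C@H]2C[C@H](O)[C@@H](CO)O2)c(=O)[nH]c1=O` differs from compound 2 by ethynyloxy in place of (methylsulfonyl)methyl on an aromatic carbon. Among the measured compounds shown here, no measured step swaps one group at this position for another of this kind, so the step from compound 1 to compound 2 bears on the present change only by fixing the starting point of compound 2 at the limit. From a limit, a move beyond the scatter can show up only as a lower number; a moderate downward step is expected, an at least 4.0-fold lower number from compound 2 to compound 3 (0.60 log units; beyond the scatter), with a further limit remaining possible. Compound 3 is expected near 50000 nM, within 5000 nM to 200000 nM.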

Compound 3, half-maximal inhibitory concentration: > 200000 nM
Compound 3: a limit, no number; the forecaster's own chance of this, stated with the estimate: 45%; middle value at least 4.0-fold (0.60 log units) away from the limit.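

In this assay compound 3 is recorded at > 200000 nM, which is a limit and not a number. With ethynyloxy in place of nitro the result is an at least 1500-fold higher number from compound 1 to compound 3 (3.18 log units; beyond the scatter), so both replacements of nitro shown, this one and (methylsulfonyl)methyl, end far up the scale, and nitro remains the only group at this position with a measured number. The step between the two replacements cannot be read, and the series now rests largely on a single ceiling: the limit of > 200000 nM in this assay, at which 2 of the 3 values shown sit.

How far each replacement lies beyond that limit stays unknown, so ethynyloxy and (methylsulfonyl)methyl cannot be ranked against each other, and the compounds shown do not tell which feature of nitro goes with the measured value. From the compounds shown here alone, whether a group such as fluoro, an amine or a carboxylic acid on this aromatic carbon would give a measured number in this assay also stays open.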